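Hydroxy at the para position of a trihydroxy-free benzoyl series

This account rests on a few compounds, and the source may have more. Where it says the series, first, only, none or still open, it means among the compounds named here.

Three analogues sharing one core have been tested in a functional assay on HepG2 cells (Homo sapiens) for cytotoxicity, read by MTT assay, with a stated time of 48 h; on this read-out lower numbers stand for stronger inhibition and higher numbers for weaker inhibition: compound 1 `COc1cc(-c2nnc3n2NC(c2ccco2)C(C(=O)c2ccccc2C)S3)cc(OC)c1OC` gives 63000 nM, compound 2 `COc1cc(-c2nnc3n2NC(c2ccco2)C(C(=O)c2ccc(Cl)cc2)S3)cc(OC)c1OC` gives 78600 nM, and compound 3 `COc1cc(-c2nnc3n2NC(c2ccco2)C(C(=O)c2ccccc2)S3)cc(OC)c1OC` gives 90900 nM. Compound 3 returns the highest of the three numbers, yet its distance from both neighbours is small: a 1.4-fold higher number from compound 1 to compound 3 (0.16 log units; within the scatter) and a 1.2-fold higher number from compound 2 to compound 3 (0.06 log units; within the scatter), each within the scatter. Compound 4 `COc1cc(-c2nnc3n2NC(c2ccco2)C(C(=O)c2ccc(O)cc2)S3)cc(OC)c1OC` differs from compound 3 by hydroxy in place of hydrogen on an aromatic carbon. Within the data shown here, no measured step introduces a hydroxy group, but the two changes at the same aromatic carbon, a 1.4-fold higher number from compound 1 to compound 3 (0.16 log units; within the scatter) and a 1.2-fold higher number from compound 2 to compound 3 (0.06 log units; within the scatter), were both within the scatter. A step of similar size is therefore expected for compound 4, a 1.1-fold lower number from compound 3 to compound 4 (0.03 log units; within the scatter), with no shift beyond the scatter. Compound 4 is estimated at 85000 nM in this assay, within a range of 40000 nM to 180000 nM.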

Compound 4, half-maximal inhibitory concentration: > 100000 nM
Compound 4 was reported as a limit (the forecaster's own chance of this, stated with the estimate: 10%); middle value at least 1.1-fold (0.07 log units) away from the limit.
By their numbers in this assay, from the lowest: compounds 1, 2 and 3 (each within the scatter of the next). At a limit, above all of these: compound 4.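

In this assay compound 4 is reported as a limit, > 100000 nM, the only value of this kind in the series: the limit of > 100000 nM in this assay, at which 1 of the 4 values shown sits. Its steps therefore give only floors: an at least 1.1-fold higher number from compound 3 to compound 4 (0.04 log units; that floor lies within the scatter), an at least 1.2-fold higher number from compound 2 to compound 4 (0.10 log units; that floor lies within the scatter) and an at least 1.5-fold higher number from compound 1 to compound 4 (0.20 log units; that floor lies within the scatter). Hydroxy at this aromatic carbon thus gives no sign of a lower number, and unlike the earlier changes there, its step has no fixed size.

From the compounds shown here alone, how far the true step extends past its floor stays open. So does whether an amine or a carboxylic acid on the same carbon would move the number beyond the scatter.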